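A few compounds are considered here, and "the series" means these few. Any claim that something is new, unique, unknown or untested is made for them only; others in the source may bear on it.

Measured compounds:
Compound 1 `CCc1nc(-c2ccc(OC)c(OC)c2)c(C(=O)N2CCN(c3cccc(Cl)c3)CC2)o1`: "not active" (no number reported)
Compound 2 `CCc1nc(-c2ccccc2F)c(C(=O)N2CCN(c3cccc(Cl)c3)CC2)o1`: 139 nM
Compound 3 `CCc1nc(-c2ccccc2F)c(C(=O)N2CCN(c3cccc(OC)c3)CC2)o1`: 607 nM

In a functional assay on HL-60 cells (Homo sapiens) for inhibition, read by MTT assay, with a stated time of 72 h (a higher number here means a weaker inhibitor, a lower number a stronger inhibitor), compound 2 gives 139 nM, the lowest of the two numbers shown; compound 3 gives 607 nM, and compound 1 has no number at all. Going by the values given here, the one measured step, a 4.4-fold higher number from compound 2 to compound 3 (0.64 log units; beyond the scatter), concerns the chloro group on a different ring and does not bear on the change at hand. Compound 4 `O=C(c1oc(C2CCCCC2)nc1-c1ccccc1F)N1CCN(c2cccc(Cl)c2)CC1` arises from compound 2 by cyclohexyl in place of ethyl on an aromatic carbon. Among the compounds with values here, no measured pair tests this exchange, so no step beyond the scatter is expected in either direction in this assay. Compound 4 is therefore estimated at 160 nM, within 50 nM to 600 nM, meaning an expected step of a 1.2-fold higher number from compound 2 to compound 4 (0.06 log units; within the scatter).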

Compound 4, half-maximal inhibitory concentration: "not active" (no number reported)
Compound 4 has no reported number here; no gap can be computed for the estimate.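

Compound 4 gives no number in this assay, so no step from compound 2 can be read, and no supporting data explain this result. The compounds shown leave open how groups of intermediate size between ethyl and cyclohexyl would behave here.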